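This account rests on a few compounds, and the source may have more. Where it says the series, first, only, none or still open, it means among the compounds named here.

Compound 1 `Cc1ccc(-c2nn(-c3ccccc3)cc2-c2nc3ccccc3n2C(=O)c2cncc(C)c2)cc1` belongs to a small set of three close relatives whose tolerability has been measured in an ADME assay on HEK-293T cells (Homo sapiens) for cytotoxicity, read by MTT assay, with a stated time of 24 h; a lower number here means that less compound is tolerated, a higher number that more compound is tolerated. In this assay compound 1 gives 155000 nM. Its two companions are compound 2 `Cc1cncc(C(=O)n2c(-c3cn(-c4ccccc4)nc3-c3ccc(C(F)(F)F)cc3)nc3ccccc32)c1`, which gives 123000 nM, and compound 3 `O=C(c1ccc(Cl)cc1)n1c(-c2cn(-c3ccccc3)nc2-c2ccc(F)cc2)nc2ccccc21`, which gives 179000 nM. Compound 1 sits second highest of the three numbers, but all three lie within the scatter of one another, so the set shows no real spread in how much compound the cells tolerate.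

The step of interest leads from compound 1 to compound 4 `Cc1ccc(-c2nn(-c3ccccc3)cc2-c2nc3ccccc3n2C(=O)c2cccnc2)cc1`: hydrogen in place of methyl on an aromatic carbon. Compound 4 has not yet been measured in this assay.

Among the compounds with values here, only one measured step bears on this, and only loosely: a 1.3-fold lower number from compound 1 to compound 2 (0.10 log units; within the scatter), a swap of one small group for another on an aromatic carbon elsewhere in the molecule, which did not move the number beyond the scatter. Within the data shown here, no measured pair shows the loss of a methyl at the place changed here. Given that the one comparable swap left the reading essentially unchanged, the expectation for compound 4 is a 1.0-fold higher number from compound 1 to compound 4 (0.01 log units; within the scatter), that is, no step beyond the scatter. Compound 4 is therefore estimated to give about 160000 nM, with a likely range from 90000 nM to 290000 nM.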

Compound 4, half-maximal cytotoxic concentration: 189000 nM
Beside the measured number, compound 4's estimate is 1.2-fold (0.07 log units) below it; the measured number falls inside the stated range.
By their numbers in this assay, from the lowest: compounds 2, 1, 3 and 4 (each within the scatter of the next).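

Replacing the methyl with hydrogen turns the 5-methylpyridin-3-yl group into pyridin-3-yl and gives a 1.2-fold higher number from compound 1 to compound 4 (0.09 log units; within the scatter) in this assay. Within the data shown here, this is the first direct reading at this place, on an aromatic carbon two atoms from the ring nitrogen: the earlier compounds offered no pair that differed here, whereas this pair shows that, for these two compounds, the methyl can be absent without the cells' tolerance moving beyond the scatter. The measurements offer no explanation for this outcome.

Going by these compounds, only methyl and hydrogen are represented at this place, so it remains open whether an amine, a carboxylic acid, a methoxy group or a longer chain such as propyl would also leave the number within the scatter. This single pair also leaves open whether the same swap would give a similar result with a different group on the other parts of the molecule, such as the trifluoromethyl group of compound 2.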